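A few compounds are considered here, and "the series" means these few. Any claim that something is new, unique, unknown or untested is made for them only; others in the source may bear on it.

Series values in an ADME assay on cells (Hepatocyte, Mus musculus) for cytotoxicity, read by MTT assay, with a stated time of 24 h; a higher number here means that more compound is tolerated, a lower number that less compound is tolerated:

- compound 1 `FC(F)(F)c1ccc(-c2nn(-c3ccccc3)cc2-c2nc3ccccc3[nH]2)cc1`: 159000 nM
- compound 2 `Cc1ccc(-c2nn(-c3ccccc3)cc2-c2nc3ccccc3n2S(=O)(=O)c2ccccc2)cc1`: 189000 nM
- compound 3 `Cc1ccc(-c2nn(-c3ccccc3)cc2-c2nc3ccccc3n2S(=O)(=O)c2ccc(C)cc2)cc1`: 102000 nM

Compound 3, at 102000 nM, lies within the scatter of both compound 1 and compound 2, so the three values do not separate in this assay.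

The next compound is compound 4 `Cc1ccc(-c2nn(-c3ccccc3)cc2-c2nc3ccccc3n2S(=O)(=O)c2ccc(F)cc2)cc1`, with fluoro in place of methyl on an aromatic carbon. The change sits on a six-membered aromatic ring of carbon only, para to a large group, and turns (4-methylphenyl)sulfonyl into (4-fluorophenyl)sulfonyl.

Among the measured compounds shown here, only one measured step bears on this change. It is a 1.9-fold lower number from compound 2 to compound 3 (0.27 log units; within the scatter), which places methyl on an aromatic carbon where hydrogen stood. For the measured compounds named here, no measured step involves fluoro, and compound 1 is not linked to the others by a single-place step. With that one step inside the scatter, no change beyond the scatter is expected in this assay on replacing methyl with fluoro.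

The estimate amounts to a 1.3-fold higher number from compound 3 to compound 4 (0.12 log units; within the scatter), an expected shift that stays within the scatter. For compound 4 the expected value is 135000 nM, with an estimated range of 70000 nM to 250000 nM.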

Compound 4, half-maximal cytotoxic concentration: 167000 nM
Compound 4: the middle estimate sits 1.2-fold (0.09 log units) below what was measured; the measured number falls inside the stated range.
By their numbers in this assay, from the lowest: compounds 3, 1, 4 and 2 (each within the scatter of the next).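

In this assay fluoro in place of methyl gives a 1.6-fold higher number from compound 3 to compound 4 (0.21 log units; within the scatter), which gives this position, para to a large group, its first reading with a halogen rather than a carbon substituent. Fluoro in place of hydrogen gives a 1.1-fold lower number from compound 2 to compound 4 (0.05 log units; within the scatter), so with the earlier methyl step, hydrogen, methyl and fluoro on this six-membered aromatic ring all lie within the scatter of one another, and the position shows no measurable dependence on which of the three it carries in this hepatocyte read-out. No supporting data are available to account for this flat picture.

On these data alone, whether that flatness extends to substituents of a different kind at the same position, such as an amine, a carboxylic acid or a longer chain, remains open, since the three seen here span only a narrow set of groups. Compound 1 still differs from the other compounds in more than one place, so the separate contributions of its trifluoromethyl group and of the sulfonyl group on the shared core also remain unresolved.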